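This account rests on a few compounds, and the source may have more. Where it says the series, first, only, none or still open, it means among the compounds named here.

The measured compounds:
Compound 1, `N=C(NCCCc1c[nH]cn1)NCCC(c1ccc(F)cc1)c1ccccn1`, gives 22.4 nM in a functional assay on ileum for antagonist activity at histamine H1 receptor (Cavia porcellus); a higher number here means weaker binding, a lower number tighter binding.
Compound 2, `N=C(NCCCc1c[nH]cn1)NCCC(c1cc(F)cc(F)c1)c1ccccn1`, gives 275 nM in this assay.
Compound 3, `N=C(NCCCc1c[nH]cn1)NCCC(c1ccccn1)c1ccccn1`, gives 389 nM in this assay.

Compound 1 stands at the lowest number of the three, the tightest binding shown. The two measured steps from it both replace the 4-fluorophenyl group: a 12-fold higher number from compound 1 to compound 2 (1.09 log units; beyond the scatter) and a 17-fold higher number from compound 1 to compound 3 (1.24 log units; beyond the scatter). Compound 4, `N=C(NCCCc1c[nH]cn1)NCCC(c1ccncc1)c1ccc(F)cc1`, instead keeps the 4-fluorophenyl group and alters the other aromatic ring: pyridin-4-yl in place of pyridin-2-yl on a saturated chain carbon bound to an aromatic carbon and a saturated chain carbon. For the measured compounds named here, no measured step touches that ring, so the data give no direct guide to the size or direction of this change. With compound 1 already the tightest binder shown, a modest rise in the number is taken as the more likely outcome. Compound 4 is therefore expected to give about 60 nM, within 15 nM to 300 nM, a step of a 2.7-fold higher number from compound 1 to compound 4 (0.43 log units; beyond the scatter).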

Compound 4, dissociation constant: 37.2 nM
Compound 4: the middle estimate sits 1.6-fold (0.21 log units) above what was measured; the measured number falls inside the stated range.
By their numbers in this assay, from the lowest: compounds 1 and 4 (each within the scatter of the next); then compounds 2 and 3 (each within the scatter of the next).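

Replacing pyridin-2-yl with pyridin-4-yl on this saturated chain carbon gives a 1.7-fold higher number from compound 1 to compound 4 (0.22 log units; within the scatter) in this assay. For the compounds shown here, this is the first measured change to this aromatic ring, and unlike the replacements of the 4-fluorophenyl group, it stays within the scatter. Nothing shown explains why these two groups give such similar numbers. Still open, as far as these compounds go, is whether pyridin-3-yl or a plain phenyl ring at this carbon would also stay within the scatter of compound 1. Also open, from the compounds shown here alone, is whether pyridin-4-yl would behave the same way alongside 3,5-difluorophenyl.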